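The source may hold more compounds than are shown below. What is called first, only, known or untested is meant among the compounds shown, and "the series" means these compounds.

Measured in a functional assay on BT-549 cells (Homo sapiens) for inhibition, read by sulforhodamine B assay, with a stated time of 48 h; a higher number here means a weaker inhibitor of growth, a lower number a stronger inhibitor of growth:

- Compound 1 `Cc1ccc(NC(=O)/C=C/c2ccccc2)c(C(N)=O)c1`: 4880 nM
- Compound 2 `NC(=O)c1cc(Br)ccc1NC(=O)/C=C/c1ccccc1`: 1410 nM

Compound 2 holds the lower of these two numbers, so it is the stronger inhibitor of growth so far. Compound 3 `NC(=O)c1cc(I)ccc1NC(=O)/C=C/c1ccccc1` differs from it in one place: iodo in place of bromo on an aromatic carbon. In words, this is iodo in place of bromo on an aromatic carbon. Going by the values given here, only one measured step bears on this change: a 3.5-fold lower number from compound 1 to compound 2 (0.54 log units; beyond the scatter), a modest move that came with bromo in place of methyl at that same carbon. One step involving a different swap says little about the size of the next, so no step beyond the scatter is expected in this assay, with only a slight lean toward a lower number. The expected step is a 1.2-fold lower number from compound 2 to compound 3 (0.09 log units; within the scatter). For compound 3 the estimated value is 1150 nM, with an expected range of 480 nM to 2700 nM.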

Compound 3, concentration for 50% growth inhibition: 9470 nM
Compound 3: middle estimate off by 8.2-fold (0.92 log units), on the low side; measured number above the stated range.
By their numbers in this assay, from the lowest: compound 2; then compounds 1 and 3 (each within the scatter of the next).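

In this assay this carbon, meta to a carbamoyl group and para to a large group, does not treat the two halogens alike: iodo in place of bromo, one heavy atom for another, gives a 6.7-fold higher number from compound 2 to compound 3 (0.83 log units; beyond the scatter). Iodo in place of methyl gives a 1.9-fold higher number from compound 1 to compound 3 (0.29 log units; within the scatter), so among these three groups the lower number belongs to bromo alone and does not carry over to the iodo of compound 3. No measurement at hand explains this difference between bromo and iodo.

From the compounds shown here alone, whether chloro or fluoro at this carbon would follow bromo or iodo stays open, as does the outcome with an amine or a methoxy group there. Three compounds also cannot show whether the advantage of bromo holds when another part of the core changes.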